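From Benzoyl to (5-Nitrofuran-2-yl)carbonyl in One Ester

The source may report more compounds than this note shows. Statements on the series, on what has been measured and on what is new or still open speak of the compounds shown alone.

Measured compounds:
Compound 1, `CC1=CC[C@H]2[C@@H]1CC=C(C)[C@@H](CC[C@H]1[C@]3(C)CC[C@H](O)C(C)(C)O[C@H]3CC[C@@]1(C)O)C2(C)C`: > 50000 nM, a limit of the assay
Compound 2, `CC1=CC[C@H]2[C@H](CC[C@]2(C)O)C(C)(C)[C@@H]1CC[C@H]1[C@]2(C)CC[C@H](OC(=O)c3ccccc3)C(C)(C)O[C@H]2CC[C@@]1(C)O`: 16100 nM
Compound 3, `CC1=CC[C@H]2[C@@H]1CC=C(C)[C@@H](CC[C@H]1[C@]3(C)CC[C@H](OC(=O)c4ccncc4)C(C)(C)O[C@H]3CC[C@@]1(C)O)C2(C)C`: 19100 nM

In a functional assay on MDA-MB-231 cells (Homo sapiens) for antiproliferative activity, read by MTT assay, with a stated time of 72 h (on this read-out higher numbers stand for weaker inhibition and lower numbers for stronger inhibition), compound 1 reaches only the assay limit > 50000 nM. Compound 3 gives 19100 nM. Compound 2 gives 16100 nM, the lower of the two numbers, with compound 3 within the scatter of it. Among the compounds with values here, the single measured step, an at least 2.6-fold lower number from compound 1 to compound 3 (0.41 log units; beyond the scatter), concerns (pyridin-4-yl)carbonyl in place of hydrogen on an oxygen on a saturated carbon and rests on (the limit of > 50000 nM in this assay, at which 1 of the 3 values shown sits). Compound 4, `CC1=CC[C@H]2[C@H](CC[C@]2(C)O)C(C)(C)[C@@H]1CC[C@H]1[C@]2(C)CC[C@H](OC(=O)c3ccc([N+](=O)[O-])o3)C(C)(C)O[C@H]2CC[C@@]1(C)O`, differs from compound 2 by 5-nitrofuran-2-yl in place of phenyl on a carbonyl carbon. Within the data shown here, no measured pair exchanges one aryl group for another within the ester, so no step beyond the scatter is expected; the estimated change is a 1.2-fold lower number from compound 2 to compound 4 (0.06 log units; within the scatter). Compound 4 is thus expected to give 14000 nM, between 5000 nM and 40000 nM.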

Compound 4, half-maximal inhibitory concentration: 11100 nM
Estimate against measurement, compound 4: 1.3-fold (0.10 log units) above; the measured number falls inside the stated range.
By their numbers in this assay, from the lowest: compounds 4, 2 and 3 (each within the scatter of the next). At a limit, above all of these: compound 1.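

Within the data shown here, this is the only exchange of one aryl group for another within the ester, and in this assay it reads a 1.5-fold lower number from compound 2 to compound 4 (0.16 log units; within the scatter). Placing 5-nitrofuran-2-yl on the carbonyl carbon instead of phenyl, a five-membered aromatic ring with hydrogen-bond acceptors for a carbon-only six-membered one, thus leaves compound 4 indistinguishable from compound 2. Nothing measured here points to a cause for this step. Still open, from the compounds shown here alone, is whether an aryl ester carrying an amine or a carboxylic acid, or a longer chain in place of the aryl group, would move the number beyond the scatter.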